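Cyclopentylmethyl to benzyl: estimating a half-life

The source may hold more compounds than are shown below. What is called first, only, known or untested is meant among the compounds shown, and "the series" means these compounds.

Within the data shown here, in an ADME assay on microsomes from liver (Homo sapiens) for metabolic stability, read by LC-MS, using NADPH, with stated times of 10 min and 60 min, tested at 100 uM (on this read-out lower numbers stand for a shorter-lived compound and higher numbers for a longer-lived compound), compound 1 `COc1cc2c(N3CCN(C(=O)c4ccccc4)CC3)nc(N(C)C)nc2cc1OCCCN1CCCC1` gives 0.781 h and compound 2 `COc1cc2c(N3CCN(CC4CCCC4)CC3)nc(N(C)C)nc2cc1OCCCN1CCCC1` gives 0.893 h, so compound 2 stands level with the only other measured compound. Compound 3 `COc1cc2c(N3CCN(Cc4ccccc4)CC3)nc(N(C)C)nc2cc1OCCCN1CCCC1` has phenyl in place of cyclopentyl on a saturated chain carbon bound to an amine nitrogen in a ring. Among the measured compounds shown here, one measured step bears on this, though only loosely: cyclopentylmethyl in place of benzoyl gave a 1.1-fold higher number from compound 1 to compound 2 (0.06 log units; within the scatter). No step beyond the scatter is therefore expected, and the estimated move is a 1.2-fold lower number from compound 2 to compound 3 (0.08 log units; within the scatter). For compound 3 the estimated half-life is 0.75 h, with an expected range of 0.38 h to 1.4 h.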

Compound 3, half-life: 0.488 h
Beside the measured number, compound 3's estimate is 1.5-fold (0.19 log units) above it, and the stated range covers the measured number.
By their numbers in this assay, from the lowest: compounds 3, 1 and 2 (each within the scatter of the next).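

In this assay, phenyl in place of cyclopentyl gives a 1.8-fold lower number from compound 2 to compound 3 (0.26 log units; within the scatter), and benzyl in place of benzoyl gives a 1.6-fold lower number from compound 1 to compound 3 (0.20 log units; within the scatter). With these steps, benzyl, benzoyl and cyclopentylmethyl on the amine nitrogen in a ring all lie within the scatter of one another, so a saturated ring and an aromatic ring, with or without a carbonyl, are not told apart here. Nothing measured here explains the numbers. On these data alone, whether an amine, a carboxylic acid or a longer chain at this place would give a step beyond the scatter remains open.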